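Replacing 4-methylpiperazin-1-yl in a short-lived compound

The source may hold more compounds than are shown below. What is called first, only, known or untested is meant among the compounds shown, and "the series" means these compounds.

In an ADME assay on a cell-free system (plasma, Mus musculus) for metabolic stability, read by LC-MS, tested at 2 uM (on this read-out lower numbers stand for a shorter-lived compound and higher numbers for a longer-lived compound), compound 1 `CC(C)CNC(=O)n1c(=O)oc2c(C3CCN(C)CC3)cccc21` gives 0.667 h. Compound 2 `CN1CCN(c2ccc3c(c2)oc(=O)n3C(=O)NCCCCc2ccccc2)CC1` gives no number, only the assay limit < 0.0834 h. Compound 3 `CCN1CCC(c2ccc3c(c2)oc(=O)n3C(=O)NCCCCc2ccccc2)CC1` differs from compound 2 by 1-ethylpiperidin-4-yl in place of 4-methylpiperazin-1-yl on an aromatic carbon, with 1-ethylpiperidin-4-yl in place of 4-methylpiperazin-1-yl on an aromatic carbon, and the rest of the structure is unchanged. Among the compounds with values here, no measured step bears on this change. The expected step of an at least 1.0-fold higher number from compound 2 to compound 3 (0.03 log units; that floor lies within the scatter) in this assay is therefore none beyond the usual scatter. Compound 3 is estimated at 0.09 h, with an expected range of 0.045 h to 0.3 h.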

Compound 3, half-life: 0.833 h
Compound 3: middle estimate off by 9.3-fold (0.97 log units), on the low side; the measured number lies above the stated range.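

In this assay, the position on the aromatic carbon proves sensitive to this change: 1-ethylpiperidin-4-yl in place of 4-methylpiperazin-1-yl gives an at least 9.9-fold higher number from compound 2 to compound 3 (0.99 log units; beyond the scatter). Within the data shown here, this is the first step read at this position, and it lies beyond the scatter. Its size is only a floor, as compound 2 has a limit and not a number: the limit of < 0.0834 h in this assay, at which 1 of the 3 values shown sits.

The compounds shown leave open whether the step goes with the ring atom or with ethyl in place of methyl. A 4-ethylpiperazin-1-yl group at this place would separate the two.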